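Removing One Phenyl from Compound 1

The source may hold more compounds than are shown below. What is called first, only, known or untested is meant among the compounds shown, and "the series" means these compounds.

Compound 1 `CCCCCCCc1cn(C(c2ccccc2)c2ccccc2)nn1` gives 19400 nM in an assay on isolated protein for inhibition of Aromatase (Homo sapiens), read by fluorescence and colorimetric assay, with a stated time of 30 min (on this read-out lower numbers stand for stronger inhibition and higher numbers for weaker inhibition), the highest of the three numbers shown. Compound 2 `c1ccc(C(c2ccccc2)n2cc(C3CCCCC3)nn2)cc1` gives 13700 nM, and compound 3 `Clc1ccc(OCc2cn(C(c3ccccc3)c3ccccc3)nn2)cc1` gives 13400 nM; the steps of a 1.4-fold lower number from compound 1 to compound 2 (0.15 log units; within the scatter), a 1.4-fold lower number from compound 1 to compound 3 (0.16 log units; within the scatter) and a 1.0-fold lower number from compound 2 to compound 3 (0.01 log units; within the scatter) all remain within the scatter. Compound 4 `CCCCCCCc1cn(Cc2ccccc2)nn1` differs from compound 1 by hydrogen in place of phenyl on a saturated chain carbon bound to an aromatic carbon and an aromatic nitrogen. Among the compounds with values here, none of the measured steps touches this place; each of them changes the group on the aromatic carbon, so they give no guide to the size or direction of this change. Compound 4 is therefore expected to show a step of a 1.3-fold higher number from compound 1 to compound 4 (0.11 log units; within the scatter), which lies within the scatter. For compound 4 the estimate is 25000 nM, with a range from 8000 nM to 80000 nM.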

Compound 4, half-maximal inhibitory concentration: 9530 nM
Beside the measured number, compound 4's estimate is 2.6-fold (0.42 log units) above it; the measured number falls inside the stated range.
By their numbers in this assay, from the lowest: compounds 4, 3, 2 and 1 (each within the scatter of the next, the first and the last beyond it).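

Hydrogen in place of phenyl on the saturated chain carbon bound to an aromatic carbon and an aromatic nitrogen gives a 2.0-fold lower number from compound 1 to compound 4 (0.31 log units; beyond the scatter) and so, although modest, is the first step here to lie beyond the scatter; the steps among compound 1, compound 2 and compound 3 at the aromatic carbon all stay within it. The second phenyl of compound 1 is therefore not required for this level of inhibition. No measurement shown accounts for the change.

On these data alone, whether a methyl or an amine at this place would move the number further remains open. So does whether the same change would give a similar step with the cyclohexyl of compound 2 or the (4-chlorophenoxy)methyl of compound 3.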